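The source may report more compounds than this note shows. Statements on the series, on what has been measured and on what is new or still open speak of the compounds shown alone.

Measured so far:
- compound 1 `CC1CCN(c2c(S(=O)(=O)c3ccc(F)cc3)cnc3cc(Cl)ccc23)CC1`: 91%
- compound 2 `CC1CCN(c2c(S(=O)(=O)c3cccc(F)c3)cnc3c(F)cccc23)CC1`: 62%

In an assay on isolated protein for displacement of a labelled ligand from metabotropic glutamate receptor 5 (Homo sapiens), with a stated time of 60 min, tested at 1 uM (on this read-out higher numbers stand for more inhibition at the one concentration tested (going by the name of the read-out) and lower numbers for less inhibition), compound 1 gives 91% and stands highest of the two numbers shown. Compound 2 gives 62% in this assay, a number well below that of compound 1 and outside the usual scatter. For the measured compounds named here, these two compounds differ in more than one place, so their gap cannot be tied to any single change; it shows only that compound 1 sits near the top of what this read-out can report.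

Compound 3 `CC1CCN(c2c(S(=O)(=O)c3ccc(C#N)cc3)cnc3cc(Cl)ccc23)CC1` is not yet measured. Against compound 1 it carries one change: cyano in place of fluoro on an aromatic carbon. Going by the values given here, no pair of measured compounds here differs by this kind of swap, so nothing in the data tells how large its effect is. Because compound 1 already gives 91% in this assay, there is little room to rise; the expected step of a number 9 percentage points lower from compound 1 to compound 3 (within the scatter) is therefore a small drop, likely within the scatter. Compound 3 is estimated to give 82% in this assay, with a range from 60% to 95%.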

Compound 3, a percentage reported as inhibition, at one concentration (the size of the read-out at that concentration, not a potency): 70%
The estimate for compound 3 lay 12 percentage points above the measured number, and the stated range covers the measured number.
By their numbers in this assay, from the lowest: compounds 2 and 3 (each within the scatter of the next); then compound 1.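

In this assay, the change from 4-fluorophenyl to 4-cyanophenyl gives the first reading tied to a single place, as the rest of compound 1 stays the same: a number 21 percentage points lower from compound 1 to compound 3 (beyond the scatter), a modest step but one beyond the scatter. The group on this aromatic carbon, para to a large group, therefore matters to the read-out, and here cyano in place of fluoro goes with less inhibition at the one concentration tested, something the earlier pair could not show since compound 1 and compound 2 differ in more than one place. Nothing measured here says why the number falls with this swap.

One swap at one position cannot tell whether the fall is particular to cyano or would come with other replacements for fluoro, such as a methoxy group, an amine or a carboxylic acid on the same carbon. It also leaves open whether the same change would lower the number by a similar amount on the core of compound 2, or with the fluoro moved elsewhere on the ring.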